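Extending an Ether Substituent on the Shared Core

The source may hold more compounds than are shown below. What is called first, only, known or untested is meant among the compounds shown, and "the series" means these compounds.

Measured compounds:
compound 1, `O=C(/C=C/c1ccc2c(c1)B(O)OC2)c1ccccc1F`: 2200 nM
compound 2, `COc1ccccc1C(=O)/C=C/c1ccc2c(c1)B(O)OC2`: 3100 nM

Among the measured compounds shown here, compound 2 holds the higher of the two numbers in a functional assay on MDA-MB-231 cells (Homo sapiens) for cytotoxicity, read by MTT assay, with a stated time of 48 h (a higher number here means a weaker inhibitor, a lower number a stronger inhibitor), but the only step between them, a 1.4-fold higher number from compound 1 to compound 2 (0.15 log units; within the scatter), lies within the scatter, so neither compound can be called the stronger inhibitor on this evidence. Compound 3, `COCOc1ccccc1C(=O)/C=C/c1ccc2c(c1)B(O)OC2`, differs from compound 2 by methoxy in place of hydrogen on a saturated chain carbon bound to an oxygen on an aromatic ring. For the measured compounds named here, no measured pair shows this change; the one step that bears on it at all is a 1.4-fold higher number from compound 1 to compound 2 (0.15 log units; within the scatter), which exchanged one small group on the aromatic carbon for another and left the number essentially unchanged. With nothing in the data pointing to a substantial shift in either direction, the expectation for compound 3 is a step of a 1.1-fold higher number from compound 2 to compound 3 (0.05 log units; within the scatter), that is, none beyond the scatter. Compound 3 is therefore estimated at 3500 nM in this assay, with a range from 1500 nM to 8500 nM.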

Compound 3, half-maximal inhibitory concentration: 10200 nM
Compound 3: the middle estimate sits 2.9-fold (0.46 log units) below what was measured; the measured number lies above the stated range.
By their numbers in this assay, from the lowest: compounds 1 and 2 (each within the scatter of the next); then compound 3.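

Methoxymethoxy is the first group at this aromatic carbon to move the number beyond the scatter in this assay, with a 3.3-fold higher number from compound 2 to compound 3 (0.52 log units; beyond the scatter) for the added methoxy on the saturated chain carbon. Measured against fluoro, the same group gives a 4.6-fold higher number from compound 1 to compound 3 (0.67 log units; beyond the scatter), so compound 3 is a weaker inhibitor than both earlier compounds, whereas the exchange of fluoro for methoxy stayed within the scatter. Nothing in the available data accounts for this loss of activity.

The compounds shown leave open whether the higher number goes with the oxygen added to the chain or with the length of the chain, a question that a propoxy group, with carbon in that place, would address. They also leave open how a hydroxyl group or an amine at this aromatic carbon would compare with methoxy and methoxymethoxy.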